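What Quinolin-8-yl Might Do for Compound 3

A few compounds are considered here, and "the series" means these few. Any claim that something is new, unique, unknown or untested is made for them only; others in the source may bear on it.

In a functional assay on Shh Light II cells (Mus musculus) for inhibition, read by a luciferase reporter (a lower number here means a stronger inhibitor, a higher number a weaker inhibitor), compound 1 (`CC(C)c1ccccc1NC(=O)N1CCC(c2nc(-c3ccc4ccccc4n3)no2)CC1`) gives 480 nM, and compound 2 (`CC(=O)N1CCC(NC(=O)N2CCC(c3nc(-c4ccc5ccccc5n4)no3)CC2)CC1`) gives 500 nM. Compound 2 therefore stands level with compound 1, the two numbers lying within the scatter of each other. Compound 3 (`O=C(Nc1cccc2cccnc12)N1CCC(c2nc(-c3ccc4ccccc4n3)no2)CC1`) has not yet been measured. It carries quinolin-8-yl in place of 1-acetylpiperidin-4-yl on an amide-type nitrogen.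

Within the data shown here, only one measured step bears on this change. At the same nitrogen, 1-acetylpiperidin-4-yl took the place of 2-isopropylphenyl, giving a 1.0-fold higher number from compound 1 to compound 2 (0.02 log units; within the scatter), a step within the scatter. Two quite different groups thus read alike at this place, and that single step is the whole of the evidence. On these data alone, how a group with one aromatic ring of carbon only and one aromatic ring with a hetero atom will read remains untested, so the range must stay wide. The expected change is a 1.1-fold lower number from compound 2 to compound 3 (0.05 log units; within the scatter), an estimate of no step beyond the scatter in either direction. In this assay, compound 3 is estimated at 450 nM, with an expected range from 150 nM to 1400 nM.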

Compound 3, half-maximal inhibitory concentration: 1400 nM
The estimate for compound 3 lay 3.1-fold (0.49 log units) below the measured number, and the stated range covers the measured number.
By their numbers in this assay, from the lowest: compounds 1 and 2 (each within the scatter of the next); then compound 3.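

In this assay, the nitrogen of the urea-type link turns out not to be indifferent to the group it carries: quinolin-8-yl in place of 1-acetylpiperidin-4-yl gives a 2.8-fold higher number from compound 2 to compound 3 (0.45 log units; beyond the scatter), and quinolin-8-yl in place of 2-isopropylphenyl gives a 2.9-fold higher number from compound 1 to compound 3 (0.46 log units; beyond the scatter). Both steps are modest, yet they lie beyond the scatter, so the level reading of the first two compounds does not hold for every group at this place, and compound 3 is the weakest inhibitor of the three. No measurement at hand accounts for these steps.

The compounds shown leave open whether the higher number goes with the hetero atom of quinolin-8-yl or with its two fused aromatic rings, a question that naphthalen-1-yl on the same nitrogen would address. Also open, on these data alone, is how a group bearing an amine or a carboxylic acid would read at this place, and whether any group at this nitrogen can bring the number below those of compound 1 and compound 2.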